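The source may hold more compounds than are shown below. What is called first, only, known or untested is meant among the compounds shown, and "the series" means these compounds.

The series shares one core, a methylamide-bearing pyridine linked through an ether to a phenyl ketone that carries a double-bonded chain ending in a substituted phenyl ring. Compound 1 `CNC(=O)c1cc(Oc2ccc(C(=O)/C=C/c3ccc(OC)c(OC)c3OC)cc2)ccn1` carries a trimethoxyphenyl at the end of that chain; in a functional assay on PC-3 cells (Homo sapiens) for cytotoxicity, read by MTT assay, with a stated time of 72 h (a lower number here means a stronger inhibitor, a higher number a weaker inhibitor), compound 1 gives "not determined" (no result reported), since no result was reported for it. Compound 2 `CNC(=O)c1cc(Oc2ccc(C(=O)/C=C/c3ccc([N+](=O)[O-])cc3)cc2)ccn1` carries a 4-nitrophenyl there, and in this assay compound 2 gives 11100 nM. Among the compounds with values here, that is the only number available, so compound 2 stands alone as the single point of reference for the whole set.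

Compound 3 `CNC(=O)c1cc(Oc2ccc(C(=O)/C=C/c3ccc(Cl)cc3Cl)cc2)ccn1` is the next member. It differs from compound 2 in a single place: 2,4-dichlorophenyl in place of 4-nitrophenyl on a double-bonded chain carbon bound to a double-bonded chain carbon. Within the data shown here, no step between two measured compounds exists here, so there is nothing to calibrate the size of such a change against. The expectation is therefore cautious: a step from compound 2 to compound 3 of a 1.4-fold lower number from compound 2 to compound 3 (0.14 log units; within the scatter) is estimated, which would stay close to the usual scatter, with a slight lean toward the stronger side. Compound 3 is thus expected to give an estimated 8000 nM in this assay, with a plausible range from 2500 nM to 25000 nM.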

Compound 3, half-maximal inhibitory concentration: 9220 nM
Compound 3: middle estimate off by 1.2-fold (0.06 log units), on the low side, within the range that was stated.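

Placing 2,4-dichlorophenyl in place of 4-nitrophenyl on a double-bonded chain carbon bound to a double-bonded chain carbon gives a 1.2-fold lower number from compound 2 to compound 3 (0.08 log units; within the scatter) in this assay, the first step in this series that can be read at all. At this place, therefore, 4-nitrophenyl, which holds hydrogen-bond acceptors and nitrogen and oxygen atoms, and 2,4-dichlorophenyl, which holds no hydrogen-bond acceptors and carries chlorine instead, cannot be told apart in this read-out, so this one exchange leaves the number where it was within the scatter. Nothing at hand bears on why the two compounds read alike.

Going by these compounds, a single step says nothing about how far this sameness extends, and it remains open whether a plain phenyl, a ring bearing an amine or a carboxylic acid, or a longer chain in place of the double-bonded chain would separate from compound 2 and compound 3 in this assay. The compounds shown also leave open what happens when the methylamide of the shared core is replaced, for example by a primary amide or a carboxylic acid.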